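The source may hold more compounds than are shown below. What is called first, only, known or untested is meant among the compounds shown, and "the series" means these compounds.

Going by the values given here, compound 3 `Cc1ccc(Oc2ccc(/C=N/NC(=S)Nc3ccc(Cl)cc3)cc2)cc1` is one of three compounds measured in a physicochemical assay for lipophilicity, in phosphate buffer, measured as octanol-water partition, with a stated time of 24 h; a higher number here means a more lipophilic compound, a lower number a more polar compound. In this assay compound 3 gives 5.97, compound 1 `Cc1cc(Oc2ccc(/C=N/NC(=S)Nc3ccc(F)cc3)cc2)ccc1Cl` gives 6.07 and compound 2 `S=C(N/N=C/c1ccc(Oc2ccc3ccccc3c2)cc1)Nc1ccc(Cl)cc1` gives 6.96. Compound 3 thus shows the lowest of the three numbers, though its gap to compound 1 lies within the scatter, while compound 2 stands clearly higher.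

Compound 4 `Cc1ccc(Oc2ccc(/C=N/NC(=S)Nc3ccc(F)cc3)cc2)cc1` differs from compound 3 in one place: fluoro in place of chloro on an aromatic carbon. Among the compounds with values here, the only single-point step measured so far, a number 0.99 log units lower from compound 2 to compound 3 (beyond the scatter), concerns a different exchange at the oxygen-linked ring and does not bear on a chloro-to-fluoro exchange. Compound 1 also carries a fluoro on the aminophenyl ring, but it differs from compound 3 in a second place, so the two values show only that they sit close together.

Within the data shown here, with no direct precedent, compound 4 is expected to come out somewhat lower than compound 3, by an estimated a number 0.52 log units lower from compound 3 to compound 4 (beyond the scatter). The value expected for compound 4 in this assay is 5.45, with a range from 5 to 5.9.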

Compound 4, partition coefficient: 5.48
For compound 4 the middle estimate is 0.03 log units below the measured one, within the range that was stated.
By their numbers in this assay, from the lowest: compound 4; then compounds 3 and 1 (each within the scatter of the next); then compound 2.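

In this assay, going by these compounds alone, the exchange at the aromatic carbon para to a large group gives the first direct reading for this position: fluoro in place of chloro yields a number 0.49 log units lower from compound 3 to compound 4 (beyond the scatter). With the 4-fluorophenyl end held fixed, the change at the oxygen-linked ring also registers, 4-methylphenyl in place of 4-chloro-3-methylphenyl giving a number 0.59 log units lower from compound 1 to compound 4 (beyond the scatter). Nothing measured alongside these values bears on why the number moves at either place.

Going by these compounds, the chloro-to-fluoro step is read only with 4-methylphenyl on the oxygen, so whether it holds with the naphthalen-2-yl group of compound 2 remains open. On these data alone, how a methoxy group, a nitrile or a trifluoromethyl group would read at this position also remains open.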